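Hydroxyalkyl thioether variants of a shared pyrazolopyrimidine-like core

The source may report more compounds than this note shows. Statements on the series, on what has been measured and on what is new or still open speak of the compounds shown alone.

Compound 1 `CC(C)c1n[nH]c2c(NCc3ccc(-c4ccccn4)cc3)nc(SCC(O)C(F)(F)F)nc12` was tested in a functional assay on HT cells (Homo sapiens) for antiproliferative activity, read by fluorescence, with a stated time of 72 h (on this read-out higher numbers stand for weaker inhibition of growth and lower numbers for stronger inhibition of growth), and gives 690 nM, which stands second highest of the three numbers; the nearest neighbour is compound 2 `CC(C)c1n[nH]c2c(NCc3ccc(-c4ccccn4)cc3)nc(SCC(C)(C)O)nc12` with 507 nM, and the furthest is compound 3 `CC(C)c1n[nH]c2c(NCc3ccc(-c4ccccn4)cc3)nc(SC(CO)C(C)C)nc12` with 980 nM. The step of a 1.4-fold lower number from compound 1 to compound 2 (0.13 log units; within the scatter) and the step of a 1.4-fold higher number from compound 1 to compound 3 (0.15 log units; within the scatter) both sit within the scatter, as does a 1.9-fold higher number from compound 2 to compound 3 (0.29 log units; within the scatter). The change to compound 4 `CC(C)c1n[nH]c2c(NCc3ccc(-c4ccccn4)cc3)nc(SCCCO)nc12` is 2-hydroxyethyl in place of 2,2,2-trifluoro-1-hydroxyethyl on a saturated chain carbon bound to a sulfur. The three measured steps all exchange one hydroxyalkyl group on the sulfur for another and none of them moves the number beyond the scatter, so the same is expected here: a change a 1.0-fold higher number from compound 1 to compound 4 (0.01 log units; within the scatter) with no clear direction. Compound 4 is therefore estimated to give 700 nM in this assay, with a range from 350 nM to 1400 nM.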

Compound 4, concentration for 50% growth inhibition: 109 nM
Compound 4: the middle estimate sits 6.4-fold (0.81 log units) above what was measured; measured number outside the range, below it.
By their numbers in this assay, from the lowest: compound 4; then compounds 2, 1 and 3 (each within the scatter of the next).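

In this assay, among the compounds shown here, the group on the sulfur proves able to move the number, which the earlier compounds did not show: the change to 3-hydroxypropyl gives a 6.3-fold lower number from compound 1 to compound 4 (0.80 log units; beyond the scatter) and also a 4.7-fold lower number from compound 2 to compound 4 (0.67 log units; beyond the scatter) and a 9.0-fold lower number from compound 3 to compound 4 (0.95 log units; beyond the scatter) as steps beyond the scatter, whereas every step among the first three compounds stayed within it. Compound 4 is the only one of the four with an unbranched chain on the sulfur and the only one clearly separated from the rest, though a single compound cannot show that the missing branch is what counts. Nothing available accounts for this gain.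

As far as these compounds go, it remains open whether the hydroxyl at the end of the chain is needed or whether a terminal amine or carboxylic acid would serve as well. From the compounds shown here alone, it is also open whether a longer chain, such as 4-hydroxybutyl, would lower the number further or raise it again.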